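Nitro to Amino on the Diaryl Ether Anilines

The compounds below may be only part of what the source reports. "The series", "measured", "known", "first", "only" and "open" are said of these compounds alone.

For the measured compounds named here, compound 3 `Nc1cc(Oc2cccc(NCc3cccc(OC(F)(F)F)c3)c2)ccc1[N+](=O)[O-]` is the only member of this group with a numbered result: in a functional assay on PLC5 cells (Homo sapiens) for inhibition, read by MTT assay, with a stated time of 24 h (a higher number here means a weaker inhibitor, a lower number a stronger inhibitor), compound 3 gives 8300 nM. Compound 1 `N#Cc1ccc(Oc2cccc(NCc3cccc(OC(F)(F)F)c3)c2)cc1` reaches in this assay only a limit, > 15000 nM. Compound 2 `CNC(=O)c1cc(Oc2cccc(NCc3cccc(OC(F)(F)F)c3)c2)ccn1` likewise reaches only a limit, > 15000 nM. Going by the values given here, the steps of an at least 1.8-fold lower number from compound 1 to compound 3 (0.25 log units; that floor lies within the scatter) and an at least 1.8-fold lower number from compound 2 to compound 3 (0.25 log units; that floor lies within the scatter) are the sole measured steps, and both start from the limit of > 15000 nM in this assay, at which 2 of the 3 values shown sit. Compound 4 `Nc1ccc(Oc2cccc(NCc3cccc(OC(F)(F)F)c3)c2)cc1N` differs from compound 3 by amino in place of nitro on an aromatic carbon. Among the compounds with values here, no measured step touches that particular change, and with both neighbours sitting at the limit the expectation is a step of a 1.4-fold higher number from compound 3 to compound 4 (0.16 log units; within the scatter) in this assay, with a real chance of another limit. Compound 4 is therefore expected to give 12000 nM, within 4000 nM to 35000 nM.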

Compound 4, half-maximal inhibitory concentration: > 15000 nM
Compound 4 gave a limit, no number; the forecaster's own chance of this, stated with the estimate: 45%; middle value at least 1.2-fold (0.09 log units) away from the limit.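

In this assay, amino in place of nitro on this aromatic carbon, ortho to an amino group, gives an at least 1.8-fold higher number from compound 3 to compound 4 (0.25 log units; that floor lies within the scatter), so the nitro of compound 3 is not shown to matter beyond the scatter. The steps to compound 4 from compound 1 and from compound 2 join two limits and cannot be read. The step to compound 4 is only a floor because the values crowd at one end: the limit of > 15000 nM in this assay, at which 3 of the 4 values shown sit.

As far as these compounds go, whether a carboxylic acid or a sulfonamide on this carbon would give a number clearly lower than that of compound 3 stays open.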